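Methylsulfonyl in place of hydrogen on compound 2

This account rests on a few compounds, and the source may have more. Where it says the series, first, only, none or still open, it means among the compounds named here.

Compound 1 `CC1(COc2ccc(OC(F)(F)F)cc2)Cn2cc([N+](=O)[O-])nc2O1` - > 64000 nM (a limit)
Compound 2 `CC1(COc2ccc(OC(F)(F)F)cc2)Cn2ccnc2O1` - > 64000 nM (a limit)

In an ADME assay on MRC5 cells (Homo sapiens) for cytotoxicity, read by fluorescence, with a stated time of 72 h (on this read-out lower numbers stand for stronger inhibition and higher numbers for weaker inhibition), compound 2 gives > 64000 nM and this is a limit, not a number. For the measured compounds named here, the series so far offers only the limit of > 64000 nM in this assay, at which 2 of the 2 values shown sit, as its evidence, so compound 2 has no readable position of its own.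

The next compound is compound 3 `CC1(COc2ccc(OC(F)(F)F)cc2)Cn2c(S(C)(=O)=O)cnc2O1` with this change: methylsulfonyl in place of hydrogen on an aromatic carbon.

Going by the values given here, one measured step bears on it, also a swap on an aromatic carbon: a step that the two limits leave unreadable from compound 1 to compound 2 with hydrogen in place of nitro. That step has no readable size to carry over. With that single precedent, no step beyond the usual scatter is expected in this assay and another limit is the likeliest report. The expected change is an at least 1.0-fold lower number from compound 2 to compound 3 (0.02 log units; that floor lies within the scatter) and it remains an estimate. For compound 3 the estimated value is 60000 nM with an expected range from 25000 nM to 64000 nM as the likely span.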

Compound 3, half-maximal inhibitory concentration: > 64000 nM
Compound 3: only a limit was reported; the forecaster's own chance of this, stated with the estimate: 80%; at least 1.0-fold (0.02 log units) between middle value and limit.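

In this assay, for the compounds shown here, compound 2 and compound 3 each give only a limit, not a number, so no step between them can be read. The series offers a single reading so far: the limit of > 64000 nM in this assay, at which 3 of the 3 values shown sit.

The compounds shown leave open whether methylsulfonyl or nitro in place of hydrogen changes the result in this assay at all, since no compound has yet given a readable value.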